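The compounds below may be only part of what the source reports. "The series", "measured", "known", "first", "only" and "open" are said of these compounds alone.

In a functional assay on DLD-1 cells (Homo sapiens) for cytotoxicity, with a stated time of 48 h (a lower number here means a stronger inhibitor, a higher number a weaker inhibitor), two compounds built on a shared core have so far been measured. Compound 1 `CC(C)COc1ccc2oc(/C=C/[S+](C)[O-])cc(=O)c2c1` gives 5000 nM, and compound 2 `CCCCC(=O)Oc1ccc2oc(/C=C/[S+](C)[O-])cc(=O)c2c1` gives 6700 nM. Among the compounds with values here, compound 2 therefore stands within the scatter of compound 1, its only measured neighbour, and the two numbers cannot be ranked. The next compound to be tested is compound 3 `COc1ccc2oc(/C=C/[S+](C)[O-])cc(=O)c2c1`. The change leading to it is methyl in place of butylcarbonyl on an oxygen on an aromatic ring; in words, methyl in place of butylcarbonyl on an oxygen on an aromatic ring. Within the data shown here, only one measured step bears on this change: a 1.3-fold higher number from compound 1 to compound 2 (0.13 log units; within the scatter). That step also exchanged the group on an oxygen on an aromatic ring, and it stayed within the scatter. It is a single step with a different pair of groups, so it offers limited guidance, and the range must stay wide. Even so, no shift beyond the scatter is expected in this assay, and no clear direction can be assigned. The expected step is a 1.1-fold lower number from compound 2 to compound 3 (0.05 log units; within the scatter). The estimated value for compound 3 is 6000 nM, expected to lie between 2500 nM and 15000 nM.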

Compound 3, half-maximal inhibitory concentration: 5700 nM
Compound 3: middle estimate off by 1.1-fold (0.02 log units), on the high side; the range from low to high includes it.
By their numbers in this assay, from the lowest: compounds 1, 3 and 2 (each within the scatter of the next).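

In this assay, the group on an oxygen on an aromatic ring now spans three quite different substituents, and the numbers stay together. Butylcarbonyl carries a double bond outside aromatic rings and a hydrogen-bond acceptor, while methyl carries neither, yet this exchange gives only a 1.2-fold lower number from compound 2 to compound 3 (0.07 log units; within the scatter), and the comparison with the branched ether gives a 1.1-fold higher number from compound 1 to compound 3 (0.06 log units; within the scatter). Isobutyl, butylcarbonyl and methyl on this oxygen therefore cannot be ranked, and neither shortening the group to methyl nor exchanging the ether for the ester separates these compounds, although no measurement at hand explains why the values stay so close.

The compounds shown carry only these three groups at this place, so it remains open whether a free hydroxyl, an amine or a carboxylic acid on a longer chain would also leave the number within the scatter. They also leave open whether any change elsewhere on the shared core would move the value beyond the scatter.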